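Swapping the aryl substituent on the shared anilino core

The compounds below may be only part of what the source reports. "The series", "measured", "known", "first", "only" and "open" are said of these compounds alone.

Measured compounds:
compound 1 `O=C1C=C(Nc2ccccc2F)C(=O)c2c1nc1n2[C@H]2OC[C@@H](O)[C@H]2OC1` gives 5120 nM
compound 2 `Cc1ccc(NC2=CC(=O)c3c(nc4n3[C@H]3OC[C@@H](O)[C@H]3OC4)C2=O)cc1` gives 6590 nM
compound 3 `O=C1C=C(Nc2cccc(F)c2)C(=O)c2c1nc1n2[C@H]2OC[C@@H](O)[C@H]2OC1` gives 6440 nM

All three were tested in a functional assay on HeLa cells (Homo sapiens) for inhibition, read by sulforhodamine B assay; on this read-out lower numbers stand for stronger inhibition and higher numbers for weaker inhibition. The numbers sit close together: the nearest neighbour of compound 2 is compound 3, and the furthest is compound 1, yet both gaps fall within the usual scatter, so no order among the three can be claimed. Among the compounds with values here, the only single-place step among them, a 1.3-fold higher number from compound 1 to compound 3 (0.10 log units; within the scatter), also stays within the scatter.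

Compound 4 `O=C1C(Nc2cccc(Cl)c2)=CC(=O)c2c1nc1n2[C@H]2OC[C@@H](O)[C@H]2OC1` has not yet been measured. It differs from compound 2 by 3-chlorophenyl in place of 4-methylphenyl on an amine nitrogen. Within the data shown here, no measured pair shows a methyl replaced by a chlorine, and no measured pair shows a 4-substituted phenyl replaced by a 3-substituted one, so the step from compound 1 to compound 3 is the only one that bears on it, and it moved the number very little. Compound 4 carries its chlorine at the same ring position as the fluorine of compound 3, and compound 3 gives 6440 nM. Compound 4 is therefore expected to land close to its neighbours in this assay, with a step of a 1.2-fold lower number from compound 2 to compound 4 (0.08 log units; within the scatter) that is not expected to exceed the scatter. The estimate for compound 4 is 5500 nM, within a range from 2500 nM to 12000 nM.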

Compound 4, half-maximal inhibitory concentration: 7970 nM
Compound 4: middle estimate off by 1.4-fold (0.16 log units), on the low side, within the range that was stated.
By their numbers in this assay, from the lowest: compounds 1, 3, 2 and 4 (each within the scatter of the next).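

In this assay, the step of a 1.2-fold higher number from compound 2 to compound 4 (0.08 log units; within the scatter) stays within the scatter, so the exchange of (4-methylphenyl)amino for (3-chlorophenyl)amino on this amine nitrogen leaves no readable difference. The earlier step had only replaced 2-fluorophenyl with 3-fluorophenyl, keeping the same halogen on the ring, whereas this one replaces a methyl with a chlorine and also alters where the substituent sits. This place on the shared core therefore accepts a second, different kind of exchange without a change that can be read in this cell assay, though nothing shown explains why.

The step changes the substituent and its place on the phenyl ring together, so the compounds shown do not separate the two, and 4-chlorophenyl or 3-methylphenyl would be needed to tell them apart. As far as these compounds go, with only fluorine, chlorine and methyl on the phenyl ring here, it remains open whether a carboxylic acid, a dimethylamino group or a longer alkyl chain at this place would move the number beyond the scatter.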